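The compounds below may be only part of what the source reports. "The series", "measured", "known", "first", "only" and "open" are said of these compounds alone.

Measured compounds:
compound 1 `CC(=O)c1cc(-c2ccccc2)cc2cc(-c3ccccc3)[nH]c12` gives 65.8%
compound 2 `COc1ccc(-c2cc(C(C)=O)c3[nH]c(-c4ccccc4)cc3c2)cc1` gives 30.8%

For the measured compounds named here, in a functional assay on MCF7 cells (Homo sapiens) for cytotoxicity, read by MTT assay, with a stated time of 2 days, tested at 100 uM (on this read-out higher numbers stand for a weaker effect at the one concentration tested and lower numbers for a stronger effect), compound 1 stands highest of the two numbers measured so far, with compound 2 the nearest and lower. Going by the values given here, the one measured step, a number 35 percentage points lower from compound 1 to compound 2 (beyond the scatter), is a large one, well beyond the scatter. Compound 3 `COc1ccc(-c2cc3cc(-c4ccccc4)cc(C(C)=O)c3[nH]2)cc1` is the unmeasured member. It differs from compound 1 by methoxy in place of hydrogen on an aromatic carbon, the methoxy sitting para to a large group on the phenyl borne by the five-membered ring of the shared core, whereas in compound 2 the same change sits on the other phenyl. The step from compound 1 to compound 2 is therefore the only one that bears on it, and only in part, since the place is not the same. A drop in this assay is expected, but smaller and less certain than that step. Compound 3 is estimated at 45%, within 20% to 70%, a step of a number 20.8 percentage points lower from compound 1 to compound 3 (beyond the scatter) expected.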

Compound 3, a percentage reported as activity, at one concentration (the size of the read-out at that concentration, not a potency): 43.5%
Compound 3: middle estimate off by 1.5 percentage points, on the high side; low and high end bracket the measured number.
By their numbers in this assay, from the lowest: compound 2; then compound 3; then compound 1.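

In this assay, the change from phenyl to 4-methoxyphenyl also lowers the number when made on the second phenyl of the shared core, giving a number 22.3 percentage points lower from compound 1 to compound 3 (beyond the scatter). The lowering is therefore not confined to one phenyl. The place does appear to set its size, however: this step is labelled modest, whereas a number 35 percentage points lower from compound 1 to compound 2 (beyond the scatter) is labelled large.

On these data alone, how an amine, a hydroxy group or a longer ethoxy chain would read at this place remains open, as does the outcome of methoxy on both phenyls together. Nothing measured here accounts for the lower numbers.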